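Adding a Sulfamoyl Group to Compound 3

The compounds below may be only part of what the source reports. "The series", "measured", "known", "first", "only" and "open" are said of these compounds alone.

Three compounds have been measured in an in vitro functional assay on HEK285-7 cells for antagonist activity at prostaglandin D2 receptor 2 (Homo sapiens), read by BRET and beta-arrestin recruitment; a higher number here means a larger maximal response, a lower number a smaller maximal response:

Compound 1, `Cc1nc(-c2ccc(Cl)cc2)c(CC(=O)O)s1`, gives 50%.
Compound 2, `CCC(c1ccccc1)c1nc(-c2ccc(Cl)cc2)c(CC(=O)O)s1`, gives 50%.
Compound 3, `O=C(O)Cc1sc(C(c2ccc(F)cc2)c2ccc(F)cc2)nc1-c1ccccc1`, gives 80%.

Among these three, compound 3 reaches the highest maximal response in this assay. Compound 1 and compound 2 both sit beneath it by a margin beyond the scatter, and the two of them stand within the scatter of each other, so no order between them can be read. No pair of these compounds differs in only one place, so no single-point step is available to guide an expectation.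

Compound 4, `NS(=O)(=O)c1cccc(-c2nc(C(c3ccc(F)cc3)c3ccc(F)cc3)sc2CC(=O)O)c1`, has not yet been measured in this assay. It differs from compound 3 as follows: sulfamoyl in place of hydrogen on an aromatic carbon. Among the measured compounds shown here, nothing among the measured compounds shows what a sulfamoyl group does to the maximal response in this assay, so the direction of the step is open. On that basis the step from compound 3 to compound 4 is estimated to be a number 5 percentage points lower from compound 3 to compound 4 (within the scatter), that is, no change beyond the scatter. For compound 4 the expected maximal response in this assay is therefore 75%, with a range from 50% to 100%.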

Compound 4, largest response reached (reported as efficacy), in percent of the reference or control that the assay uses: 55%
Estimate against measurement, compound 4: 20 percentage points above; the range from low to high includes it.
By their numbers in this assay, from the lowest: compounds 1, 2 and 4 (each within the scatter of the next); then compound 3.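

In this assay, among the compounds shown here, the change from phenyl to 3-sulfamoylphenyl gives a number 25 percentage points lower from compound 3 to compound 4 (beyond the scatter), and this is the first step that can be read at a single place. It shows that the maximal response is not indifferent to what stands on this aromatic carbon, meta to a large group: here, sulfamoyl in place of hydrogen carries the response down, with the rest of compound 3 unchanged. No measurement bears on why the response falls, so the step stands as an observed change without an explanation.

The compounds shown leave open whether this drop belongs to sulfamoyl itself or would follow any substituent on this carbon, such as a methyl group, a chlorine atom, an amine or a carboxylic acid. They also leave open how sulfamoyl would act on the other carbons of the same ring, and whether the step would hold on the core of compound 1 or compound 2 rather than that of compound 3.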